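The source may report more compounds than this note shows. Statements on the series, on what has been measured and on what is new or still open speak of the compounds shown alone.

Working notes on the series. Compound 1 `COC(=O)c1ccc(NCc2cncn2Cc2ccccc2N)cc1-c1ccccc1`, compound 2 `c1ccc(-c2ccc(Cn3cncc3CNc3ccccc3-c3ccccc3)cc2)cc1` and compound 3 `O=C(OC1CCCCC1)c1ccc(NCc2cncn2Cc2ccc(-c3ccccc3)cc2)cc1-c1ccccc1` share one core and have been run in a toxicity assay on NIH3T3 cells (Mus musculus) for cytotoxicity, read by resazurin assay; on this read-out lower numbers stand for an effect already at smaller amounts and higher numbers for an effect only at larger amounts of compound. In this assay compound 1 gives 25000 nM. For compound 2 the result in this assay is only a limit of the assay, > 10000 nM. For compound 3 the result in this assay is likewise only a limit, > 10000 nM, so compound 3 sits at the limit of > 10000 nM in this assay, at which 2 of the 3 values shown sit, and no number is known for it. Going by the values given here, no two measured compounds differ in a single place, so no measured step can be set out here, and the spread seen is the one between the number of compound 1 and the two limits.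

Compound 4 `CCOC(=O)c1ccc(NCc2cncn2Cc2ccc(-c3ccccc3)cc2)cc1-c1ccccc1` is not yet measured. It differs from compound 3 by ethyl in place of cyclohexyl on an oxygen next to a carbonyl group. Given that compound 3 rests on a limit, no shift beyond the usual scatter is expected in this assay, and the expected step is a step that the limit leaves unreadable from compound 3 to compound 4. Compound 4 is therefore expected to give about 20000 nM, with a range from 8000 nM to 50000 nM, and most likely once more only a limit.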

Compound 4, half-maximal effective concentration: > 10000 nM
Compound 4: no number, only a limit (the forecaster's own chance of this, stated with the estimate: 60%); the middle value lies beyond the limit too.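

Compound 4 gives > 10000 nM in this assay as a limit of the assay and not as a number. Compound 3 also rests on a limit, so no step can be read between compound 3 and compound 4. The compounds shown leave open whether ethyl in place of cyclohexyl on this oxygen changes the cytotoxicity read-out at all.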